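From Hexyl to Isopropylsulfonyl on a Weak Aortic Inhibitor

This account rests on a few compounds, and the source may have more. Where it says the series, first, only, none or still open, it means among the compounds named here.

Compound 1 `Fc1ccccc1Cn1nc(C2=NCCN2)c2cccnc21` gives 3200 nM in a functional assay (aorta) with Oryctolagus cuniculus as the target; a higher number here means a weaker inhibitor, a lower number a stronger inhibitor. Going by the values given here, compound 2 `CCCCCCc1cnc(-c2nn(Cc3ccccc3F)c3ncccc23)nc1N` gives 1040000 nM in this assay, the higher of the two numbers measured so far, and its gap to compound 1 lies far beyond the scatter. Compound 3 `CC(C)S(=O)(=O)c1cnc(-c2nn(Cc3ccccc3F)c3ncccc23)nc1N` differs from compound 2 in one place: isopropylsulfonyl in place of hexyl on an aromatic carbon. Among the compounds with values here, no measured pair shows how such a change acts here, so the step of a 3.5-fold lower number from compound 2 to compound 3 (0.54 log units; beyond the scatter) is expected to be modest, leaning toward a lower number. For compound 3 the estimated value is 300000 nM, within a range from 30000 nM to 3000000 nM.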

Compound 3, half-maximal inhibitory concentration: 517000 nM
Estimate against measurement, compound 3: 1.7-fold (0.24 log units) below; measured number inside the range.
By their numbers in this assay, from the lowest: compound 1; then compounds 3 and 2 (each within the scatter of the next).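

Putting isopropylsulfonyl in place of hexyl, on the aromatic carbon ortho to an amino group, gives a 2.0-fold lower number from compound 2 to compound 3 (0.30 log units; within the scatter) in this assay. At this position, then, an all-carbon chain and a group bearing sulfur and oxygen cannot be told apart in this read-out, and both compounds keep numbers in the same high range. No available evidence bears on this result.

On these data alone, what remains open is whether a different group at this carbon, such as a carboxylic acid, a dimethylamino group or a methyl group, would shift the number beyond the scatter. As far as these compounds go, it is also open whether any change here can matter at all on this core.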